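Methylating the Amine Nitrogen in a Tetrazole Analogue

The source may hold more compounds than are shown below. What is called first, only, known or untested is meant among the compounds shown, and "the series" means these compounds.

Compound 1: `FC(F)(F)c1cc(COC[C@@H](NCc2nc[nH]n2)c2ccccc2)cc(C(F)(F)F)c1` gives 5 nM in an assay on CHO cells for displacement of a labelled ligand from Substance-P receptor (Homo sapiens); on this read-out lower numbers stand for stronger inhibition and higher numbers for weaker inhibition.
Compound 2: `CN(Cc1nc[nH]n1)[C@H](COCc1cc(C(F)(F)F)cc(C(F)(F)F)c1)c1ccccc1` gives 1.4 nM in this assay.
Compound 3: `FC(F)(F)c1cc(COC[C@@H](NCc2nn[nH]n2)c2ccccc2)cc(C(F)(F)F)c1` gives 23 nM in this assay.

All three measured compounds share a core and differ only in the part attached to the amine nitrogen. Compound 1 and compound 3 differ in the ring hanging from that nitrogen: 2H-tetrazol-5-yl in place of 1H-1,2,4-triazol-3-yl on a saturated chain carbon bound to an amine nitrogen. This change costs potency, as a 4.6-fold higher number from compound 1 to compound 3 (0.66 log units; beyond the scatter) shows. Compound 1 and compound 2 differ by a single methyl group: methyl in place of hydrogen on an amine nitrogen. Here the change helps, with a 3.6-fold lower number from compound 1 to compound 2 (0.55 log units; beyond the scatter). Taken together these two changes add up to a 16-fold higher number from compound 2 to compound 3 (1.22 log units; beyond the scatter).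

Compound 4, `CN(Cc1nn[nH]n1)[C@H](COCc1cc(C(F)(F)F)cc(C(F)(F)F)c1)c1ccccc1`, has not yet been measured in this assay. It stands to compound 3 as compound 2 stands to compound 1, carrying the same change: methyl in place of hydrogen on an amine nitrogen. The place is described in the same words for both pairs, an amine nitrogen whose other neighbours are two saturated chain carbons, so the change is made at the same kind of position on a different core. On the assumption that the methyl group acts as it did between compound 1 and compound 2, compound 4 is expected to show a step of a 3.5-fold lower number from compound 3 to compound 4 (0.55 log units; beyond the scatter), because a 3.6-fold lower number from compound 1 to compound 2 (0.55 log units; beyond the scatter) is the only direct record of this change. Compound 4 is therefore estimated at 6.5 nM, with a likely range from 3 nM to 15 nM, the width allowing for the change transferring less fully onto the tetrazole core.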

Compound 4, half-maximal inhibitory concentration: 70 nM
The estimate for compound 4 lay 11-fold (1.03 log units) below the measured number; measured number outside the range, above it.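

In this assay, the methyl group on the amine nitrogen does not carry over from the core of compound 1 to the core of compound 3. Instead of the gain seen on the first core, it gives a 3.0-fold higher number from compound 3 to compound 4 (0.48 log units; beyond the scatter), and the two records of the change point in opposite directions: the same change on two cores in this assay, a 3.6-fold lower number (0.55 log units; beyond the scatter) from compound 1 to compound 2 and a 3.0-fold higher number (0.48 log units; beyond the scatter) from compound 3 to compound 4, 11-fold (1.04 log units) apart, beyond the scatter of two such steps

The same coupling appears when the ring is swapped, since the tetrazole costs far more on the methylated amine, with a 50-fold higher number from compound 2 to compound 4 (1.70 log units; beyond the scatter), and the combined result is a 14-fold higher number from compound 1 to compound 4 (1.15 log units; beyond the scatter), which is a larger loss than the ring swap alone causes on the unmethylated amine: the same change on two cores in this assay, a 4.6-fold higher number (0.66 log units; beyond the scatter) from compound 1 to compound 3 and a 50-fold higher number (1.70 log units; beyond the scatter) from compound 2 to compound 4, 11-fold (1.04 log units) apart, beyond the scatter of two such steps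

Among these compounds, this shows that, for these four compounds, the effect of the methyl group depends on which ring is present, so a step measured on one core is a poor guide to the other; it does not show why the direction reverses, and with only one pair on each core it sets no rule for the wider series.

From the compounds shown here alone, it remains open whether an ethyl group on the amine nitrogen would split the two cores in the same way as methyl. An acetyl group at that nitrogen would be a further test of whether the reversal persists.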